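Camphor-derived amino esters: ring amine swap to piperazine

A few compounds are considered here, and "the series" means these few. Any claim that something is new, unique, unknown or untested is made for them only; others in the source may bear on it.

Compound 3 `CC1(C)[C@H]2CC[C@]1(C)[C@H](OC(=O)CN1CCCC1)C2` holds the highest number of the three measured in an ADME assay on MDCK cells (Canis lupus familiaris) for cytotoxicity, read by MTT assay, with a stated time of 48 h (on this read-out higher numbers stand for lower toxicity in this test and lower numbers for higher toxicity in this test), where compound 3 gives 302000 nM. Compound 1 `CC1(C)[C@H]2CC[C@]1(C)[C@H](OC(=O)CN1CCCCC1)C2` gives 138000 nM and compound 2 `CC1(C)[C@H]2CC[C@]1(C)[C@H](OC(=O)CCN1CCCC1)C2` gives 125000 nM in this assay. Both lie beyond the scatter from compound 3, as the steps of a 2.2-fold higher number from compound 1 to compound 3 (0.34 log units; beyond the scatter) and a 2.4-fold higher number from compound 2 to compound 3 (0.38 log units; beyond the scatter) show, while the step of a 1.1-fold lower number from compound 1 to compound 2 (0.04 log units; within the scatter) stays within it.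

Compound 4 `CC1(C)[C@H]2CC[C@]1(C)[C@H](OC(=O)CN1CCNCC1)C2` differs from compound 3 by piperazin-1-yl in place of pyrrolidin-1-yl on a saturated chain carbon bound to a carbonyl carbon. Among the compounds with values here, no measured step introduces piperazin-1-yl, so only the ring-size comparison bears on it: the move from the six-membered piperidin-1-yl to the five-membered pyrrolidin-1-yl raised the number modestly in a 2.2-fold higher number from compound 1 to compound 3 (0.34 log units; beyond the scatter). Returning to a six-membered ring in compound 4 is therefore expected to give, at most, a modest step downward in this assay, a 1.5-fold lower number from compound 3 to compound 4 (0.18 log units; within the scatter), and possibly none beyond the scatter. For compound 4 the estimate in this assay is 200000 nM, with a range from 100000 nM to 450000 nM.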

Compound 4, half-maximal cytotoxic concentration: 51600 nM
Compound 4: the middle estimate sits 3.9-fold (0.59 log units) above what was measured; the measured number lies below the stated range.
By their numbers in this assay, from the lowest: compound 4; then compounds 2 and 1 (each within the scatter of the next); then compound 3.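

At this place, on a saturated chain carbon bound to a carbonyl carbon, the change to piperazin-1-yl gives the largest step in the series in this assay, a 5.9-fold lower number from compound 3 to compound 4 (0.77 log units; beyond the scatter), and compound 4 also lies beyond the scatter from the other two, with a 2.7-fold lower number from compound 1 to compound 4 (0.43 log units; beyond the scatter) and a 2.4-fold lower number from compound 2 to compound 4 (0.38 log units; beyond the scatter). Within the data shown here, compound 1 and compound 4 both carry six-membered rings, so ring size alone does not set the number here; the second ring nitrogen is the one difference in that pair. No measurement at hand gives a reason for these steps.

As far as these compounds go, whether the ring nitrogen's hydrogen matters remains open, and a morpholine ring or a piperazine with a methyl on its second nitrogen would test this at the same place. Also open, from the compounds shown here alone, is how piperazin-1-yl behaves on the longer chain of compound 2.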